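The source may hold more compounds than are shown below. What is called first, only, known or untested is meant among the compounds shown, and "the series" means these compounds.

Compound 1 `O=c1ccoc2cc(OCc3cn(Cc4cccc(Br)c4)nn3)ccc12`: > 300000 nM
Compound 2 `C#CCOc1ccc2c(=O)ccoc2c1`: > 300000 nM

In an ADME assay on L02 cells (Homo sapiens) for cytotoxicity, read by MTT assay, with a stated time of 48 h (a higher number here means a weaker inhibitor, a lower number a stronger inhibitor), compound 1 gives > 300000 nM, which is a limit of the assay rather than a number. Compound 2 gives > 300000 nM in this assay, again a limit and not a number. Where compound 1 stands is thus known only as a limit, and the same is seen in the limit of > 300000 nM in this assay, at which 2 of the 2 values shown sit. Among the measured compounds shown here, no step between two measured compounds can be computed here, since neither value is a number, and no pattern can be drawn from these two results.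

Compound 3 `O=c1ccoc2cc(OCc3cn(Cc4ccccc4F)nn3)ccc12` has not yet been measured in this assay. It differs from compound 1 in one place: 2-fluorophenyl in place of 3-bromophenyl on a saturated chain carbon bound to an aromatic nitrogen. For the measured compounds named here, with both measured compounds sitting at the limit, the data offer no size of step to lean on. The expected step of a number no higher from compound 1 to compound 3 (the limit leaves the size open) is none beyond the scatter, which means compound 3 is expected to sit at the limit as well. Compound 3 is estimated at 300000 nM, within a range from 150000 nM to 600000 nM, and the most likely outcome is that this assay once more reports only a limit.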

Compound 3, half-maximal inhibitory concentration: > 300000 nM
Compound 3: no number, only a limit; the forecaster's own chance of this, stated with the estimate: 80%; the middle value sits exactly at the limit.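

In this assay compound 3 gives > 300000 nM, which is a limit and not a number. No step between compound 1 and compound 3 can be read, since both results are limits: the limit of > 300000 nM in this assay, at which 3 of the 3 values shown sit.

The compounds shown leave open whether 2-fluorobenzyl in place of 3-bromobenzyl changes the result in this assay at all.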